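Swapping Chloro for Bromo in a Three-Compound Series

A few compounds are considered here, and "the series" means these few. Any claim that something is new, unique, unknown or untested is made for them only; others in the source may bear on it.

Compound 3 `Cc1ccc(Nc2nc(SCc3cn(Cc4ccccc4Cl)nn3)nc(-c3ccc(Cl)cc3)c2C#N)cc1` was tested in a functional assay on MCF7 cells (Homo sapiens) for inhibition, read by MTT assay, with a stated time of 72 h (on this read-out lower numbers stand for stronger inhibition and higher numbers for weaker inhibition), where compound 3 gives 14700 nM. Among the three compounds measured, this is the second highest number. Compound 1 `Cc1ccc(Nc2nc(SCc3cn(Cc4ccccc4Cl)nn3)nc(-c3ccccc3)c2C#N)cc1` gives 9420 nM in this assay, and the step of a 1.6-fold higher number from compound 1 to compound 3 (0.19 log units; within the scatter) lies within the scatter, so these two cannot be told apart. Compound 2 `Cc1ccc(Nc2nc(SCc3cn(Cc4ccccc4Cl)nn3)nc(-c3ccc(C)cc3)c2C#N)cc1` gives 30900 nM, and the step of a 2.1-fold lower number from compound 2 to compound 3 (0.32 log units; beyond the scatter) is modest but beyond the scatter. The remaining comparison, a 3.3-fold higher number from compound 1 to compound 2 (0.52 log units; beyond the scatter), is also modest.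

Compound 4 `Cc1ccc(Nc2nc(SCc3cn(Cc4ccccc4Cl)nn3)nc(-c3ccc(Br)cc3)c2C#N)cc1` has not been measured. It differs from compound 3 in one place: bromo in place of chloro on an aromatic carbon. For the measured compounds named here, no measured step swaps one halogen for another, so the expectation rests on the steps at the same position: chloro in place of hydrogen, a 1.6-fold higher number from compound 1 to compound 3 (0.19 log units; within the scatter), changed little, and chloro in place of methyl, a 2.1-fold lower number from compound 2 to compound 3 (0.32 log units; beyond the scatter), moved the number only modestly. With only these steps to go on, no step beyond the scatter is expected in this assay, and the expected step is a 1.0-fold higher number from compound 3 to compound 4 (0.01 log units; within the scatter). Compound 4 is therefore estimated at 15000 nM, with a range from 7000 nM to 35000 nM.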

Compound 4, half-maximal inhibitory concentration: 25100 nM
Compound 4: middle estimate off by 1.7-fold (0.22 log units), on the low side, within the range that was stated.
By their numbers in this assay, from the lowest: compounds 1, 3, 4 and 2 (each within the scatter of the next, the first and the last beyond it).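

In this assay, for the compounds shown here, the only halogen-for-halogen step at this position (a 1.7-fold higher number from compound 3 to compound 4 (0.23 log units; within the scatter)) lies within the scatter, so chloro and bromo cannot be told apart here. Bromo also cannot be told apart from methyl (a 1.2-fold lower number from compound 2 to compound 4 (0.09 log units; within the scatter)), yet it stands modestly clear of hydrogen (a 2.7-fold higher number from compound 1 to compound 4 (0.43 log units; beyond the scatter)), as methyl does (a 3.3-fold higher number from compound 1 to compound 2 (0.52 log units; beyond the scatter)), while chloro does not (a 1.6-fold higher number from compound 1 to compound 3 (0.19 log units; within the scatter)), so the 4-bromophenyl compound sides with the methyl compound against hydrogen even though it cannot be separated from the chloro compound either. No measurement is available that would explain these differences.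

None of the groups shown here brings the number below that of compound 1 by more than the scatter, so it remains open whether any group at this position could do so. Only hydrogen, methyl, chloro and bromo occupy this place, which leaves open what an amine, a carboxylic acid or a longer chain there would do in this assay, this assay.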